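Thiazolyl group exchange from compound 3 to compound 4

A few compounds are considered here, and "the series" means these few. Any claim that something is new, unique, unknown or untested is made for them only; others in the source may bear on it.

Measured in a functional assay on MCF7 cells (Homo sapiens) for antiproliferative activity; on this read-out lower numbers stand for stronger inhibition and higher numbers for weaker inhibition:
- compound 1 `Cc1cc(S(=O)(=O)c2ccc(C#N)cc2)c2ccccc2n1` (1380 nM)
- compound 2 `Cc1cc(S(=O)(=O)c2ccccc2[N+](=O)[O-])c2ccccc2n1` (1380 nM)
- compound 3 `CCONC(=O)c1sc(N2N=C(c3ccc(C)cc3)CC2c2cc3cc(OC)ccc3nc2Cl)nc1C` (38 nM)

Compound 3 has the lowest number of the three, and its gap to each of the other two lies beyond the scatter. Compound 1 and compound 2 show the same value. Compound 4 `COc1ccc2nc(Cl)c(C3CC(c4ccc(C)cc4)=NN3c3nc(-c4ccc(Cl)cc4)cs3)cc2c1` keeps the shared core of compound 3 and differs in one place: 4-(4-chlorophenyl)-1,3-thiazol-2-yl in place of 5-(ethoxycarbamoyl)-4-methyl-1,3-thiazol-2-yl on an amine nitrogen in a ring. The new group, 4-(4-chlorophenyl)-1,3-thiazol-2-yl, replaces 5-(ethoxycarbamoyl)-4-methyl-1,3-thiazol-2-yl on an amine nitrogen in a ring. Among the measured compounds shown here, no measured pair differs in one place only, so the data offer no direct guide to this exchange. With compound 3 (38 nM) at the low end of the measured values, a move upward seems more likely than a further drop. An estimated step of a 3.2-fold higher number from compound 3 to compound 4 (0.50 log units; beyond the scatter) is expected, modest but beyond the scatter, toward weaker inhibition in this assay. Compound 4 is estimated at 120 nM (expected range 25 nM to 600 nM).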

Compound 4, half-maximal inhibitory concentration: 38 nM
Estimate against measurement, compound 4: 3.2-fold (0.50 log units) above; the measured number falls inside the stated range.
By their numbers in this assay, from the lowest: compounds 3 and 4 (each within the scatter of the next); then compounds 1 and 2 (each within the scatter of the next).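

In this assay, among the compounds shown here, the exchange on the amine nitrogen in the five-membered non-aromatic ring gives no change at the digits printed from compound 3 to compound 4 (within the scatter) and is the first one-place comparison. The position therefore takes either 5-(ethoxycarbamoyl)-4-methyl-1,3-thiazol-2-yl or 4-(4-chlorophenyl)-1,3-thiazol-2-yl with no change beyond the scatter. In this pair, the hydrogen-bond donor of the leaving group is not needed to hold the value, and an added six-membered aromatic ring of carbon only is tolerated. Nothing at hand explains why the two groups read alike.

Still open, going by these compounds, is which part of each group matters. A carboxylic acid in place of the ethoxycarbamoyl, or a plain phenyl in place of the 4-chlorophenyl, would test this.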